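A few compounds are considered here, and "the series" means these few. Any claim that something is new, unique, unknown or untested is made for them only; others in the source may bear on it.

Measured so far in an ADME assay on microsomes from liver (Homo sapiens) for metabolic stability, read by LC-MS, tested at 1 uM; on this read-out higher numbers stand for fast clearance and lower numbers for slow clearance:
compound 1 `NCCOc1ccc([C@H]2CC[C@]3(CC2)OOC2(O3)C3CC4CC(C3)CC2C4)cc1` gives < 7 mL.min-1.g-1, a limit of the assay.
compound 2 `c1cc([C@H]2CC[C@]3(CC2)OOC2(O3)C3CC4CC(C3)CC2C4)ccc1OC1CCNCC1` gives 15 mL.min-1.g-1.
compound 3 `NCCS(=O)(=O)CCOc1ccc([C@H]2CC[C@]3(CC2)OOC2(O3)C3CC4CC(C3)CC2C4)cc1` gives 9 mL.min-1.g-1.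

Compound 3 holds the lowest of the two numbers shown; its nearest neighbour is compound 2, and a 1.7-fold lower number from compound 2 to compound 3 (0.22 log units; within the scatter). The change to compound 4 `NC(=O)C1CCN(Cc2ccc([C@H]3CC[C@]4(CC3)OOC3(O4)C4CC5CC(C4)CC3C5)cc2)CC1` is (4-carbamoylpiperidin-1-yl)methyl in place of 2-((2-aminoethyl)sulfonyl)ethoxy on an aromatic carbon. Among the measured compounds shown here, no measured step matches this change closely. For the measured compounds named here, the one step beyond the scatter, an at least 2.1-fold higher number from compound 1 to compound 2 (0.33 log units; beyond the scatter), put a piperidine ring onto the ether oxygen and raised the number; here a piperidine ring enters on a methylene carbon while the whole sulfonyl-bearing chain and its oxygen leave. The expectation for compound 4 is therefore a 1.3-fold higher number from compound 3 to compound 4 (0.12 log units; within the scatter), a number close to or a little above compound 3. The estimate for compound 4 is 12 mL.min-1.g-1, between 6 mL.min-1.g-1 and 25 mL.min-1.g-1.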

Compound 4, intrinsic clearance in microsomes: 10 mL.min-1.g-1
Compound 4: the middle estimate sits 1.2-fold (0.08 log units) above what was measured; low and high end bracket the measured number.
By their numbers in this assay, from the lowest: compounds 3, 4 and 2 (each within the scatter of the next). At a limit, below all of these: compound 1.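

In this assay, the aromatic carbon para to a large group takes (4-carbamoylpiperidin-1-yl)methyl with no step beyond the scatter against the two side chains that give numbers (a 1.1-fold higher number from compound 3 to compound 4 (0.05 log units; within the scatter); a 1.5-fold lower number from compound 2 to compound 4 (0.18 log units; within the scatter)). Against compound 1 only a floor can be read (an at least 1.4-fold higher number from compound 1 to compound 4 (0.15 log units; that floor lies within the scatter)). Compound 1 stands at a limit: the limit of < 7 mL.min-1.g-1 in this assay, at which 1 of the 4 values shown sits.

Open, as far as these compounds go, is whether a carboxylic acid or an amine in place of the carbamoyl group of compound 4, or a longer chain in place of its methyl link, gives a step beyond the scatter.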